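Replacing the chloro group of compound 3 with dimethylamino

The source may report more compounds than this note shows. Statements on the series, on what has been measured and on what is new or still open speak of the compounds shown alone.

Values in a functional assay on SW480 cells (Homo sapiens) for antiproliferative activity, read by MTT assay, with a stated time of 48 h; on this read-out higher numbers stand for weaker inhibition and lower numbers for stronger inhibition:
- Compound 1 `CC(=O)OC/C1=C/C[C@](C)(CCC=C(C)C)/C=C/[C@@H](OC(=O)C=C(C)C)[C@](C)(O)/C=C/C1=O`: 2950 nM
- Compound 2 `CC(C)=CCC[C@]1(C)/C=C/[C@@H](OC(=O)C=C(C)C)[C@](C)(O)/C=C/C(=O)/C(C(=O)O)=C\C1`: > 10000 nM (a limit of the assay, not an exact number)
- Compound 3 `CC(C)=CCC[C@]1(C)/C=C/[C@@H](OC(=O)C=C(C)C)[C@](C)(O)/C=C/C(=O)/C(CCl)=C\C1`: 390 nM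

Of the three compounds, compound 3 stands lowest at 390 nM, and compound 1 is its nearest neighbour. Compound 4 `CC(C)=CCC[C@]1(C)/C=C/[C@@H](OC(=O)C=C(C)C)[C@](C)(O)/C=C/C(=O)/C(CN(C)C)=C\C1` has not yet been measured. Its structure differs from that of compound 3 by dimethylamino in place of chloro on a saturated chain carbon bound to a double-bonded ring carbon, with dimethylamino in place of chloro on a saturated chain carbon bound to a double-bonded ring carbon.

For the measured compounds named here, two measured steps bear on this change. The first is a 7.6-fold lower number from compound 1 to compound 3 (0.88 log units; beyond the scatter), where chloro replaced acetoxy on that same carbon. The second is an at least 25-fold lower number from compound 2 to compound 3 (1.40 log units; beyond the scatter), where chloromethyl replaced carboxy. Both reached a lower number only with the chloro group in place, and neither other group matched it, so losing chloro is expected to cost activity. The expected change in this assay is a modest rise, a 5.1-fold higher number from compound 3 to compound 4 (0.71 log units; beyond the scatter). For compound 4 the estimated value is 2000 nM, with an expected range of 500 nM to 8000 nM.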

Compound 4, half-maximal inhibitory concentration: 480 nM
Compound 4: the middle estimate sits 4.2-fold (0.62 log units) above what was measured; measured number outside the range, below it.
By their numbers in this assay, from the lowest: compounds 3 and 4 (each within the scatter of the next); then compound 1. At a limit, above all of these: compound 2.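

In this assay, the saturated chain carbon bound to a double-bonded ring carbon tolerates dimethylamino as well as chloro, with a 1.2-fold higher number from compound 3 to compound 4 (0.09 log units; within the scatter), so the chloro group is not needed there for a number of this size. Compound 4 also keeps the advantage of compound 3 over the other two compounds, with a 6.1-fold lower number from compound 1 to compound 4 (0.79 log units; beyond the scatter) and an at least 20-fold lower number from compound 2 to compound 4 (1.31 log units; beyond the scatter), which shows that a group with nitrogen can do the same at this carbon. Compound 2 stands at a limit of the assay, not at an exact number: the limit of > 10000 nM in this assay, at which 1 of the 4 values shown sits.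

What the compounds shown leave open is whether another amine, such as a morpholine or piperidine ring, or a plain hydroxyl would do as well at this carbon. They also leave open whether a longer chain carrying the dimethylamino group would hold the number.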